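Notes on one ring stereocentre in the series

The compounds below may be only part of what the source reports. "The series", "measured", "known", "first", "only" and "open" are said of these compounds alone.

Compound 1 (`CCCCCCCNC[C@@H]1OC[C@H](N)[C@@H]1O`): > 128000 nM as a limit of the assay
Compound 2 (`CCCCCCCCCCCNC[C@@H]1OC[C@H](N)[C@@H]1O`): 19300 nM as measured
Compound 3 (`CCCCCCCCCCCCNC[C@@H]1OC[C@H](N)[C@H]1O`): 58100 nM as measured

All three entries come from a functional assay on B16-F10 cells (Mus musculus) for antiproliferative activity, read by MTT assay, with a stated time of 72 h (on this read-out higher numbers stand for weaker inhibition and lower numbers for stronger inhibition), as the read-out. Here compound 3 gives 58100 nM, while compound 2 gives 19300 nM. The number of compound 3 is the higher of the two, and the gap lies beyond the scatter. Compound 1 is known only by its limit.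

Compound 4 (`CCCCCCCCCCCCNC[C@@H]1OC[C@H](N)[C@@H]1O`) changes one thing against compound 3: the two compounds have the same atoms and bonds and differ only in configuration as drawn: 1 of 3 stereo elements differ; a stereocentre at a saturated ring carbon is drawn R in compound 3 and S in compound 4 (a stereocentre at a saturated ring carbon is drawn R in compound 3 and S in compound 4). Going by the values given here, the only measured step (an at least 6.6-fold lower number from compound 1 to compound 2 (0.82 log units; beyond the scatter)) concerns the chain and not configuration, so it sets no size for this change. Compound 2 at 19300 nM remains the nearest guide, so a modest move is expected. The expected step is a 2.9-fold lower number from compound 3 to compound 4 (0.46 log units; beyond the scatter) and points to a lower number. Compound 4 is estimated at 20000 nM with an expected range from 8000 nM to 50000 nM in this series.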

Compound 4, half-maximal inhibitory concentration: 10700 nM
Compound 4: middle estimate off by 1.9-fold (0.27 log units), on the high side, within the range that was stated.
By their numbers in this assay, from the lowest: compounds 4 and 2 (each within the scatter of the next); then compound 3. At a limit, above all of these: compound 1.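

In this assay, the step of a 5.4-fold lower number from compound 3 to compound 4 (0.73 log units; beyond the scatter) gives the first size for this ring stereocentre, and it can be read as a change of configuration alone: the fact that compounds 3 and 4 differ only in the configuration as drawn. With the stereocentre drawn S, the step of a 1.8-fold lower number from compound 2 to compound 4 (0.26 log units; within the scatter) stays within the scatter, so these two chains are not told apart here. Compound 1 stands at a limit, so the step of an at least 11-fold lower number from compound 1 to compound 4 (1.07 log units; beyond the scatter) gives only a bound: the limit of > 128000 nM in this assay, at which 1 of the 4 values shown sits.

As far as these compounds go, whether this stereocentre gives a step of like size on a longer chain, such as hexadecyl, stays open. From the compounds shown here alone, the part played by the other two stereo elements stays open as well.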